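Bromoacrylamide loss and para substituent swap in one series

A few compounds are considered here, and "the series" means these few. Any claim that something is new, unique, unknown or untested is made for them only; others in the source may bear on it.

Compound 1 `C=C(Br)C(=O)Nc1cccc(/C=C2\SC(=O)N(Cc3ccc(C(F)(F)F)cc3)C2=O)c1` and compound 2 `C=C(Br)C(=O)Nc1cccc(/C=C2\SC(=O)N(Cc3ccc(Cl)cc3)C2=O)c1` share a core and differ only by chloro in place of trifluoromethyl on an aromatic carbon. In a functional assay on FM3A cells (Mus musculus) for cytotoxicity, read by cell counting, with a stated time of 2 days (on this read-out lower numbers stand for stronger inhibition and higher numbers for weaker inhibition), compound 1 gives 870 nM, and compound 2 gives 1600 nM. That swap made a 1.8-fold higher number from compound 1 to compound 2 (0.26 log units; within the scatter), so the two compounds cannot be ordered on this read-out.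

Compound 3 `Nc1cccc(/C=C2\SC(=O)N(Cc3ccc(C(F)(F)F)cc3)C2=O)c1` differs from compound 1 by hydrogen in place of (1-bromoethenyl)carbonyl on a nitrogen on an aromatic ring, and this is the whole difference between the two cores. In this assay compound 3 reaches only the limit of the assay, > 250000 nM, and no number. The step is an at least 280-fold higher number from compound 1 to compound 3 (2.45 log units; beyond the scatter); how much larger it truly is cannot be said, because the limit of > 250000 nM in this assay, at which 1 of the 3 values shown sits, is where the measurement stops.

Compound 4 `Nc1cccc(/C=C2\SC(=O)N(Cc3ccc(Cl)cc3)C2=O)c1` stands to compound 3 as compound 2 stands to compound 1: chloro in place of trifluoromethyl on an aromatic carbon, the same change at the same place, now made on the core of compound 3. Since on the core of compound 1 that change gave only a 1.8-fold higher number from compound 1 to compound 2 (0.26 log units; within the scatter), no shift beyond the scatter is expected from it here either. The step from compound 3 to compound 4 is therefore expected to be a step that the limit leaves unreadable from compound 3 to compound 4. Compound 4 is accordingly expected to sit around 300000 nM, with a range from 120000 nM to 800000 nM, and most probably this assay will again report only a limit for compound 4 rather than a number.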

Compound 4, half-maximal inhibitory concentration: 246000 nM
Compound 4: middle estimate off by 1.2-fold (0.09 log units), on the high side; the measured number falls inside the stated range.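

In this assay, hydrogen in place of (1-bromoethenyl)carbonyl on a nitrogen on an aromatic ring again gives a large step on the chloro side of the series, a 150-fold higher number from compound 2 to compound 4 (2.19 log units; beyond the scatter), so both pairs that can be compared move the same way and by a step beyond the scatter, and set side by side they read: the same change on two cores in this assay, an at least 280-fold higher number (2.45 log units; beyond the scatter) from compound 1 to compound 3 and a 150-fold higher number (2.19 log units; beyond the scatter) from compound 2 to compound 4; the limit leaves it open whether they differ. Compound 3 stands at > 250000 nM, which is a limit and not a number. This leaves the exact size of the change on the trifluoromethyl side unknown, and the swap of chloro for trifluoromethyl reads here only as an at least 1.0-fold lower number from compound 3 to compound 4 (0.00 log units; that floor lies within the scatter), so it is not shown to carry over unchanged, nor to behave differently, from one core to the other: the same change on two cores in this assay, a 1.8-fold higher number (0.26 log units; within the scatter) from compound 1 to compound 2 and an at least 1.0-fold lower number (0.00 log units; that floor lies within the scatter) from compound 3 to compound 4; the limit leaves it open whether they differ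

The compounds shown leave open whether the bromine itself matters, since a plain acryloyl or an acetyl group on that nitrogen would separate the bromine from the rest of the (1-bromoethenyl)carbonyl group. They also leave open how far the small effect of the para-group swap extends, for instance to a methoxy group or a nitrile at that place on the core of compound 1.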